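A few compounds are considered here, and "the series" means these few. Any claim that something is new, unique, unknown or untested is made for them only; others in the source may bear on it.

In an ADME assay on MDCK-II cells (Canis lupus familiaris) for permeability (on this read-out lower numbers stand for lower permeability and higher numbers for higher permeability), compound 1 `CC(C)Oc1cc(Oc2ccc(S(C)(=O)=O)cc2)cc(-c2cccc(=O)[nH]2)c1` gives 18 10^-6 cm/s and compound 2 `COc1cnc(-c2cc(Oc3ccc(S(C)(=O)=O)cc3)cc(OC(C)C)c2)[nH]c1=O` gives 3.9 10^-6 cm/s as the lower of the two numbers. Compound 3 `CC(C)Oc1cc(Oc2ccc(S(C)(=O)=O)cc2)cc(-c2ncc(Cl)c(=O)[nH]2)c1` is unmeasured and carries chloro in place of methoxy on an aromatic carbon. Going by the values given here, the only measured step that bears on this is the modest drop a 4.6-fold lower number from compound 1 to compound 2 (0.66 log units; beyond the scatter) in which methoxy came in along with a change of ring. Removing methoxy reverses only part of that step, so a small rise is expected in this assay as a 1.5-fold higher number from compound 2 to compound 3 (0.19 log units; within the scatter) and it may stay within the usual scatter. Compound 3 is estimated at 6 10^-6 cm/s with 2.5 10^-6 cm/s to 14 10^-6 cm/s as its expected range.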

Compound 3, apparent permeability: 8.3 10^-6 cm/s
Compound 3: the middle estimate sits 1.4-fold (0.14 log units) below what was measured; the range from low to high includes it.
By their numbers in this assay, from the lowest: compound 2; then compound 3; then compound 1.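

On this aromatic carbon, chloro in place of methoxy gives in this assay a 2.1-fold higher number from compound 2 to compound 3 (0.33 log units; beyond the scatter) and is beyond the scatter, so a change at this one position is enough to move the number. The chloro compound still does not return to the level of the first compound: the full group change gives a 2.2-fold lower number from compound 1 to compound 3 (0.34 log units; beyond the scatter) and is also beyond the scatter. No measurement here explains either step. From the compounds shown here alone, whether fluoro, methyl or an amine at this position would give a higher or lower number remains open. So does the effect of the second ring nitrogen with only hydrogen on this carbon.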